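This account rests on a few compounds, and the source may have more. Where it says the series, first, only, none or still open, it means among the compounds named here.

Compound 1 `Cc1c(C)c2c(c(C)c1O)CCC(C)(/C=[N+](\[O-])C(C)(C)C)O2`: 6800000 nM
Compound 2 `COc1c(C)c(C)c2c(c1C)CCC(C)(/C=[N+](\[O-])C(C)(C)C)O2`: 22000000 nM
Compound 3 `CC(=O)Oc1c(C)c(C)c2c(c1C)CCC(C)(/C=[N+](\[O-])C1CC1)O2`: 7400000 nM

In a functional assay for inhibition, with Rattus norvegicus as the target (a lower number here means a stronger inhibitor, a higher number a weaker inhibitor), compound 3 gives 7400000 nM, within the usual scatter of compound 1 and clearly lower than compound 2. Compound 4 `CC(=O)Oc1c(C)c(C)c2c(c1C)CCC(C)(/C=[N+](\[O-])C(C)(C)C)O2`, not yet measured, has tert-butyl in place of cyclopropyl on a double-bonded nitrogen. Among the compounds with values here, no measured step changes that group. Within the data shown here, the only step available, a 3.2-fold higher number from compound 1 to compound 2 (0.51 log units; beyond the scatter), is methyl in place of hydrogen on an oxygen on an aromatic ring, a modest change elsewhere that bears only indirectly. No shift beyond the scatter is therefore expected, and the expected step is a 1.2-fold higher number from compound 3 to compound 4 (0.09 log units; within the scatter). Compound 4 is estimated at 9000000 nM, with an expected range of 3500000 nM to 23000000 nM.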

Compound 4, half-maximal inhibitory concentration: 19000000 nM
The estimate for compound 4 lay 2.1-fold (0.32 log units) below the measured number, within the range that was stated.
By their numbers in this assay, from the lowest: compounds 1 and 3 (each within the scatter of the next); then compounds 4 and 2 (each within the scatter of the next).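

In this assay, the group on the double-bonded nitrogen makes a measurable difference: tert-butyl in place of cyclopropyl gives a 2.6-fold higher number from compound 3 to compound 4 (0.41 log units; beyond the scatter). With tert-butyl kept, acetyl in place of methyl on the oxygen on the aromatic ring gives a 1.2-fold lower number from compound 2 to compound 4 (0.06 log units; within the scatter), which stays within the scatter. Acetyl in place of hydrogen on that oxygen gives a 2.8-fold higher number from compound 1 to compound 4 (0.45 log units; beyond the scatter), so acetyl and methyl read alike there, while hydrogen stands apart. No measurement here explains these steps. Going by these compounds, whether a longer chain or a phenyl ring on that nitrogen would shift the number remains open.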